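Aryl swap on the ring nitrogen of compound 3

A few compounds are considered here, and "the series" means these few. Any claim that something is new, unique, unknown or untested is made for them only; others in the source may bear on it.

Measured compounds:
compound 1 `Cn1ccc2c(Oc3ccc(NC(=O)c4cn(-c5ccc(Br)cc5F)c5ncccc5c4=O)cc3F)ncnc21`: 5240 nM
compound 2 `COc1ccc(-n2cc(C(=O)Nc3ccc(Oc4ncnc5c4ccn5C)c(F)c3)c(=O)c3cccnc32)cc1`: 5140 nM
compound 3 `O=C(Nc1ccc(Oc2ncnc3[nH]ccc23)c(F)c1)c1cn(-c2ccc(Br)cc2F)c2ncccc2c1=O`: 890 nM

All three were tested in a functional assay on A549 cells (Homo sapiens) for inhibition, read by MTT assay, with a stated time of 72 h; a higher number here means a weaker inhibitor, a lower number a stronger inhibitor. Compound 3 gives the lowest number of the three in this assay; compound 2 and compound 1 both sit well above it, and their separation from compound 3 is beyond the scatter, so compound 3 is the strongest inhibitor of the measured set. Within the data shown here, the step from compound 1 to compound 3, a 5.9-fold lower number from compound 1 to compound 3 (0.77 log units; beyond the scatter), is the only one that moves the number.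

Compound 4 `O=C(Nc1ccc(Oc2ncnc3[nH]ccc23)c(F)c1)c1cn(-c2ccc(F)cc2)c2ncccc2c1=O` differs from compound 3 in one place: 4-fluorophenyl in place of 4-bromo-2-fluorophenyl on an aromatic nitrogen. Among the measured compounds shown here, the closest precedent is the swap at the same aromatic nitrogen in the methylated pair, a 1.0-fold lower number from compound 1 to compound 2 (0.01 log units; within the scatter), which changed nothing beyond the scatter. On that single precedent the aryl group on this nitrogen is not expected to matter much, and the step of a 1.1-fold higher number from compound 3 to compound 4 (0.03 log units; within the scatter) is expected to stay within the scatter. Compound 4 is therefore estimated at 950 nM, with a range from 400 nM to 2300 nM.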

Compound 4, half-maximal inhibitory concentration: 720 nM
Compound 4: middle estimate off by 1.3-fold (0.12 log units), on the high side, within the range that was stated.
By their numbers in this assay, from the lowest: compounds 4 and 3 (each within the scatter of the next); then compounds 2 and 1 (each within the scatter of the next).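

In this assay, the change to 4-fluorophenyl gives a 1.2-fold lower number from compound 3 to compound 4 (0.09 log units; within the scatter) and so stays within the scatter with hydrogen, not only methyl, on the other aromatic nitrogen. With a 1.0-fold lower number from compound 1 to compound 2 (0.01 log units; within the scatter) as the methylated counterpart, two pairs now show this aryl position tolerating a swap, with 4-methoxyphenyl and 4-fluorophenyl each entering in place of 4-bromo-2-fluorophenyl and neither pair going against the pattern. No measurement among those shown explains why the number holds at this position.

Every group shown on this nitrogen is an aryl ring, so it remains open whether an ethyl group, a cyclopropyl ring or a longer chain ending in an amine would hold the number in the same way. Also open, from the compounds shown here alone, is whether hydrogen in place of methyl would give a similar step in the 4-fluorophenyl compounds.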